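The compounds below may be only part of what the source reports. "The series", "measured", "known", "first", "only" and "open" are said of these compounds alone.

In a functional assay on SK-OV-3 cells (Homo sapiens) for cytotoxicity, read by MTT assay, with a stated time of 48 h (a lower number here means a stronger inhibitor, a higher number a weaker inhibitor), compound 1 `C=CCn1c(-c2ccc(OC)cc2COCOC)cc2ccccc2c1=O` is reported only as a limit, > 100000 nM, so the starting point for this step is not a number. Compound 2 `COCOCc1cc(OC)ccc1-c1cc2ccccc2c(=O)[nH]1` gives 75500 nM. Within the data shown here, the only measured step, an at least 1.3-fold lower number from compound 1 to compound 2 (0.12 log units; that floor lies within the scatter), replaces allyl on an aromatic nitrogen and does not touch the group that changes here. Its size therefore offers little guidance, and the evidence available is confined to the limit of > 100000 nM in this assay, at which 1 of the 2 values shown sits. Compound 3 `C=CCn1c(-c2ccc(OC)cc2C=C)cc2ccccc2c1=O` keeps the allyl of compound 1 and differs from it as follows: vinyl in place of (methoxymethoxy)methyl on an aromatic carbon. Among the measured compounds shown here, with no measured step at this place, no large shift is expected in this assay, and a reading at the limit remains quite possible. The expected change is an at least 1.4-fold lower number from compound 1 to compound 3 (0.15 log units; that floor lies within the scatter), which is no firm direction given the limit at its start. Compound 3 is estimated at 70000 nM, with an expected range of 25000 nM to 100000 nM.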

Compound 3, half-maximal inhibitory concentration: 43800 nM
Beside the measured number, compound 3's estimate is 1.6-fold (0.20 log units) above it, and the stated range covers the measured number.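

In this assay, vinyl in place of (methoxymethoxy)methyl on this aromatic carbon, ortho to a large group, gives an at least 2.2-fold lower number from compound 1 to compound 3 (0.35 log units; beyond the scatter). Among these compounds, this is the first step printed as beyond the scatter, which shows that the number responds to a change at this position, where a group with two hydrogen-bond acceptors gives way to a smaller one with none. Compound 1 stands only at a limit, so the step gives a floor and not a size: the limit of > 100000 nM in this assay, at which 1 of the 3 values shown sits.

The compounds shown leave open whether the lower number goes with the double bond, the shorter group or the loss of the oxygens, and an ethyl, a hydroxymethyl or an amine at this carbon would bear on that. They also leave open whether vinyl gives a similar step on the core of compound 2, which carries hydrogen on the aromatic nitrogen.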